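A Nitro Group Added to a Weak Antiproliferative Scaffold

This account rests on a few compounds, and the source may have more. Where it says the series, first, only, none or still open, it means among the compounds named here.

Compound 1, `O=c1c2ccccc2[se]n1-c1nc(SCc2ccccc2)n[nH]1`, was tested in an ADME assay on L929 cells (Mus musculus) for antiproliferative activity, read by CCK-8 assay, with a stated time of 48 h; a lower number here means a stronger inhibitor, a higher number a weaker inhibitor. In this assay compound 1 gives > 50000 nM, which is a limit of the assay rather than a number, so only a range is known for it (the limit of > 50000 nM in this assay, at which 1 of the 2 values shown sits). Compound 2, `Cc1ccccc1CSc1n[nH]c(-n2[se]c3ccccc3c2=O)n1`, carries a methyl in place of hydrogen on an aromatic carbon; in this assay compound 2 gives 15600 nM. That single change produced an at least 3.2-fold lower number from compound 1 to compound 2 (0.50 log units; beyond the scatter).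

Compound 3, `O=c1c2ccccc2[se]n1-c1nc(SCc2ccc([N+](=O)[O-])cc2)n[nH]1`, has not yet been measured. It differs from compound 1 by nitro in place of hydrogen on an aromatic carbon. For the measured compounds named here, the only measured step starting from compound 1 is the one to compound 2, which shows that a small group added on the six-membered aromatic ring of carbon only can move the number beyond the scatter, although a nitro group is a different kind of substituent from a methyl and that step gives no direct guide to the size here. The expectation for compound 3 is therefore a modest improvement, with a real chance that the assay again reports only a limit. Compound 3 is estimated at 30000 nM, between 8000 nM and 60000 nM. That expected step is an at least 1.6-fold lower number from compound 1 to compound 3 (0.22 log units; that floor lies within the scatter).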

Compound 3, half-maximal inhibitory concentration: 7430 nM
For compound 3 the middle estimate is 4.0-fold (0.61 log units) above the measured one, outside the stated range (below it).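

Adding a nitro group to the six-membered aromatic ring of carbon only, on a carbon para to a large group, gives an at least 6.7-fold lower number from compound 1 to compound 3 (0.82 log units; beyond the scatter) in this assay. The earlier methyl step, an at least 3.2-fold lower number from compound 1 to compound 2 (0.50 log units; beyond the scatter), had shown one small group having an effect on this ring, and this result shows that a group of a different kind, at this carbon, also lowers the number beyond the scatter. Compound 1 has only a limit and not a measured number, so the new step is a floor and its true size cannot be read: the limit of > 50000 nM in this assay, at which 1 of the 3 values shown sits.

An amine or a carboxylic acid on this same carbon would help to show whether the nitro group itself matters or whether almost any added group here lowers the number. A methyl on this same carbon would also be needed before the nitro and methyl groups could be compared directly, as the compounds shown do not say how much of the gain depends on the group and how much on its place.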